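The source may hold more compounds than are shown below. What is called first, only, known or untested is meant among the compounds shown, and "the series" means these compounds.

Series notes, maximal electroshock work.

Of the compounds shown here, three have been tested in a functional assay on the whole organism (strain STD-dd) with Mus musculus as the target, in the maximal electroshock model, with a stated time of 2 h; on this read-out lower numbers stand for an effect already at smaller amounts and higher numbers for an effect only at larger amounts of compound. Compound 1 `CN(C)S(=O)(=O)Cc1noc2ccc(F)cc12` gives 32 mg/kg. Compound 2 `CN1CCN(S(=O)(=O)Cc2noc3ccc(F)cc23)CC1` gives 100 mg/kg. Compound 3 `CN(C)S(=O)(=O)Cc1noc2ccc(Br)cc12` gives 45 mg/kg. The step of a 3.1-fold higher number from compound 1 to compound 2 (0.49 log units; beyond the scatter) arises from a single change, (4-methylpiperazin-1-yl in place of dimethylamino on a sulfonyl sulfur), and is marked as lying beyond the scatter. The step of a 1.4-fold higher number from compound 1 to compound 3 (0.15 log units; within the scatter) comes from bromo in place of fluoro on an aromatic carbon, and this one stays within the scatter, so compounds 1 and 3 are not distinguished by the data in this assay. Compound 2 stands apart from both, its step from compound 3 being noted as beyond the scatter as well.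

Compound 4 `CN1CCN(S(=O)(=O)Cc2noc3ccc(Br)cc23)CC1` has not been tested in this assay. It carries the same change relative to compound 3 that compound 2 carries relative to compound 1: 4-methylpiperazin-1-yl in place of dimethylamino on a sulfonyl sulfur. The place of the change is described identically in both pairs, and the two cores differ only by bromo in place of fluoro on an aromatic carbon, a difference that left this assay's read-out within the scatter. For the measured compounds named here, on that basis the step from compound 3 to compound 4 is expected to be about the size already seen from compound 1 to compound 2, that is a 3.1-fold higher number from compound 3 to compound 4 (0.49 log units; beyond the scatter), the expectation resting on a 3.1-fold higher number from compound 1 to compound 2 (0.49 log units; beyond the scatter) as the one occurrence of this change measured so far. For compound 4 in this assay the estimate is therefore 140 mg/kg, with the likely range put at 70 mg/kg to 280 mg/kg, pending measurement.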

Compound 4, dose for half-maximal effect: 88 mg/kg
The estimate for compound 4 lay 1.6-fold (0.20 log units) above the measured number; low and high end bracket the measured number.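

For the compounds shown here, the exchange of dimethylamino for 4-methylpiperazin-1-yl on the sulfonyl sulfur gives a 2.0-fold higher number from compound 3 to compound 4 (0.29 log units; within the scatter) in this assay, and the size of this step cannot be told from that of the earlier step on the core of compound 1: the same change on two cores in this assay, a 3.1-fold higher number (0.49 log units; beyond the scatter) from compound 1 to compound 2 and a 2.0-fold higher number (0.29 log units; within the scatter) from compound 3 to compound 4, 1.6-fold (0.20 log units) apart, within the scatter of two such steps Read the other way, bromo in place of fluoro on an aromatic carbon gives a 1.1-fold lower number from compound 2 to compound 4 (0.06 log units; within the scatter), so that exchange leaves the number within the scatter with either sulfonyl substituent, and its size also agrees across the two pairs: the same change on two cores in this assay, a 1.4-fold higher number (0.15 log units; within the scatter) from compound 1 to compound 3 and a 1.1-fold lower number (0.06 log units; within the scatter) from compound 2 to compound 4, 1.6-fold (0.20 log units) apart, within the scatter of two such steps This supports carrying the sulfonyl change from one core to the other as a step of similar size, but it rests on only two pairs, and since compounds 3 and 4 are themselves not distinguished in this assay, it does not show that the change separates the compounds on the bromo-bearing core, nor does it show why the numbers behave as they do.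

As far as these compounds go, it remains open whether the same agreement would hold for other groups on the sulfonyl sulfur, such as an unsubstituted amino group or diethylamino. From the compounds shown here alone, it is equally open whether it would hold with chloro or plain hydrogen in place of the halogen on the aromatic carbon.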